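A few compounds are considered here, and "the series" means these few. Any claim that something is new, unique, unknown or untested is made for them only; others in the source may bear on it.

Working notes on the series.

Three compounds of the series have been run in a functional assay on PC-3 cells (Homo sapiens) for inhibition, read by MTT assay, with a stated time of 48 h; on this read-out higher numbers stand for weaker inhibition and lower numbers for stronger inhibition. Compound 2 `COc1cc(OC)c(-c2nc3cc(/C=C4\SC(=O)N(CC(=O)N5CCOCC5)C4=O)ccc3[nH]2)cc1OC` gives 11700 nM. Compound 1 `COc1ccc(-c2nc3cc(/C=C4\SC(=O)N(CC(=O)N5CCOCC5)C4=O)ccc3[nH]2)cc1OC` differs from compound 2 by hydrogen in place of methoxy on an aromatic carbon. Compound 1 returns only a limit of this assay, > 50000 nM; this is the limit recorded as the limit of > 50000 nM in this assay, at which 1 of the 3 values shown sits. Taken as a step, the change gives an at least 4.2-fold higher number from compound 2 to compound 1 (0.63 log units; beyond the scatter), so the loss of this methoxy is read as a weakening.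

Compound 3 `COc1cc(CN2C(=O)S/C(=C\c3ccc4[nH]c(-c5cc(OC)c(OC)c(OC)c5)nc4c3)C2=O)cc(OC)c1OC` gives 10200 nM. Its value and that of compound 2 sit within the scatter of each other, so no order is drawn between them. The difference between the core of compound 3 and the core of compound 2 is not broken down here.

Compound 4 `COc1ccc(-c2nc3cc(/C=C4\SC(=O)N(Cc5cc(OC)c(OC)c(OC)c5)C4=O)ccc3[nH]2)cc1OC` has not yet been run in this assay. It differs from compound 3 by hydrogen in place of methoxy on an aromatic carbon. For the measured compounds named here, this is the same kind of change as the one from compound 2 to compound 1, but not the same: in compound 2 the leaving methoxy sat ortho to a large group, meta to a methoxy group and para to a methoxy group, whereas in compound 3 it sits ortho to a methoxy group, meta to a large group and meta to a methoxy group. Going by the values given here, on the single measured precedent, the removal of a methoxy from compound 2 to compound 1 giving an at least 4.2-fold higher number from compound 2 to compound 1 (0.63 log units; beyond the scatter), a weakening of comparable direction is expected for compound 4, with the step estimated as a 2.9-fold higher number from compound 3 to compound 4 (0.47 log units; beyond the scatter). Compound 4 is accordingly estimated at 30000 nM, within a range of 12000 nM to 80000 nM, with a real chance that this assay again reports only a limit.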

Compound 4, half-maximal inhibitory concentration: > 50000 nM
Compound 4 was reported as a limit; the forecaster's own chance of this, stated with the estimate: 35%; at least 1.6-fold (0.22 log units) between middle value and limit.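

Compound 4 returns only a limit in this assay, which is a limit and not a number: the limit of > 50000 nM in this assay, at which 2 of the 4 values shown sit.

Going from 3,4,5-trimethoxyphenyl to 3,4-dimethoxyphenyl gives an at least 4.9-fold higher number from compound 3 to compound 4 (0.69 log units; beyond the scatter), so the loss of this methoxy again reads as a weakening, and the direction of the change carries over from one core to the other: the same change on two cores in this assay, an at least 4.2-fold higher number (0.63 log units; beyond the scatter) from compound 2 to compound 1 and an at least 4.9-fold higher number (0.69 log units; beyond the scatter) from compound 3 to compound 4; the limit leaves it open whether they differ

For the compounds shown here, this rests on only two cores, and the methoxy leaves a different place on the ring in each, so it shows a shared direction and no shared size, and the step between the two compounds that end at the limit cannot be read.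

The compounds shown leave open how the 3,4-dimethoxyphenyl compounds would rank if their values could be read as numbers, and whether a hydroxy group or a fluorine atom in place of the lost methoxy would hold the value of the parent compound. They also leave open what an amine or a carboxylic acid on a longer chain at the ring nitrogen of the shared core would do to the values in this assay.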